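A few compounds are considered here, and "the series" means these few. Any claim that something is new, unique, unknown or untested is made for them only; others in the source may bear on it.

Of the compounds shown here, three have been tested in an ADME assay on Vero cells (Chlorocebus sabaeus) for cytotoxicity, read by MTT assay, with a stated time of 72 h; on this read-out lower numbers stand for stronger inhibition and higher numbers for weaker inhibition. Compound 1 `COc1cc(/C=C/c2nnc(-c3cc([N+](=O)[O-])cn3C)o2)ccc1O` gives 203000 nM in this assay. Compound 2 `COc1cc(/C=C/c2nnc(-c3cc([N+](=O)[O-])c[nH]3)o2)ccc1O` differs from it by one change, (hydrogen in place of methyl on an aromatic nitrogen), and in this assay compound 2 gives 221000 nM. That change made a step of a 1.1-fold higher number from compound 1 to compound 2 (0.04 log units; within the scatter). Compound 3 `Cn1cc([N+](=O)[O-])cc1-c1nnc(-c2cc(-c3ccccc3)nc3ccc(Cl)cc23)o1` carries a different core; the difference between the core of compound 3 and the core of compound 1 is not broken down here. In this assay compound 3 gives 328000 nM, and its value lies within the scatter of the values of compound 2 and compound 1, so none of the three can be set apart from the others on this read-out.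

Compound 4 `O=[N+]([O-])c1c[nH]c(-c2nnc(-c3cc(-c4ccccc4)nc4ccc(Cl)cc34)o2)c1` has not yet been measured in this assay. For the measured compounds named here, it differs from compound 3 by hydrogen in place of methyl on an aromatic nitrogen, which is the same change, at the same place, as the one made from compound 1 to compound 2. Going by the values given here, since that earlier step was a 1.1-fold higher number from compound 1 to compound 2 (0.04 log units; within the scatter), the step to compound 4 is expected to be of a similar size, estimated as a 1.1-fold higher number from compound 3 to compound 4 (0.03 log units; within the scatter), because a 1.1-fold higher number from compound 1 to compound 2 (0.04 log units; within the scatter) is the only measured example of this change. On that basis compound 4 is expected to give about 350000 nM in this assay, with a likely range from 180000 nM to 700000 nM.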

Compound 4, half-maximal inhibitory concentration: 281000 nM
For compound 4 the middle estimate is 1.2-fold (0.10 log units) above the measured one; the range from low to high includes it.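

On the core of compound 3, hydrogen in place of methyl on the aromatic nitrogen gives in this assay a step of a 1.2-fold lower number from compound 3 to compound 4 (0.07 log units; within the scatter). Set beside the earlier example of this change, the step on the new core cannot be told apart from it: the same change on two cores in this assay, a 1.1-fold higher number (0.04 log units; within the scatter) from compound 1 to compound 2 and a 1.2-fold lower number (0.07 log units; within the scatter) from compound 3 to compound 4, 1.3-fold (0.10 log units) apart, within the scatter of two such steps This shows that on these two cores the change from 1-methyl-4-nitro-1H-pyrrol-2-yl to 4-nitro-1H-pyrrol-2-yl leaves the number within the scatter, so the change carried over in the sense that neither core shows a step that can be read; it does not show a direction for the change, as the two steps point opposite ways inside the scatter, and two pairs say nothing about how the change would behave on any other core or in any other assay.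

The compounds shown carry only methyl or hydrogen on that nitrogen and only a nitro group on that ring, so they leave open what a longer chain on the nitrogen, or an amine or a nitrile in place of the nitro group, would give in this assay. They also leave open whether any such group would produce a step beyond the scatter on either core.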